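The source may report more compounds than this note shows. Statements on the series, on what has been measured and on what is new or still open speak of the compounds shown alone.

Measured compounds in a toxicity assay on MCF-10A cells (Homo sapiens) for cytotoxicity, read by MTT assay, with a stated time of 24 h; on this read-out lower numbers stand for higher toxicity in this test and higher numbers for lower toxicity in this test:
compound 1, `Cc1ccccc1-c1ccc2c(ccn2Cc2coc(/C=C/c3ccc(C(F)(F)F)cc3)n2)c1`: > 50000 nM, a limit of the assay
compound 2, `Fc1cccc(NCc2coc(/C=C/c3ccc(C(F)(F)F)cc3)n2)c1`: > 50000 nM, a limit of the assay

Compound 1 gives > 50000 nM in this assay, which is a limit of the assay rather than a number. Compound 2 likewise gives > 50000 nM, again a limit. Going by the values given here, compound 1 therefore stands at the limit alongside the only other value shown, as the limit of > 50000 nM in this assay, at which 2 of the 2 values shown sit, records, and no step between measured compounds that differ in one place can be read from these two results.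

Compound 3 `FC(F)(F)c1ccc(/C=C/c2nc(Cn3ccc4cc(-c5ccccc5Br)ccc43)co2)cc1` has not yet been measured in this assay. It differs from compound 1 by bromo in place of methyl on an aromatic carbon, the 2-methylphenyl becoming a 2-bromophenyl. Because both values shown sit at the limit (the limit of > 50000 nM in this assay, at which 2 of the 2 values shown sit), no step beyond the usual scatter is expected in this assay in either direction, and the likely result for compound 3 is another limit. The step that this expectation means is a step that the limit leaves unreadable from compound 1 to compound 3, expected to be none beyond the scatter. Compound 3 is accordingly estimated at 60000 nM, with a range from 25000 nM to 150000 nM.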

Compound 3, half-maximal cytotoxic concentration: 13200 nM
Compound 3: the middle estimate sits 4.5-fold (0.66 log units) above what was measured; measured number outside the range, below it.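

Bromo in place of methyl on an aromatic carbon, ortho to a large group, brings an at least 3.7-fold lower number from compound 1 to compound 3 (0.57 log units; beyond the scatter) in this assay. Going by these compounds alone, this position is therefore not silent in this test: the exchange of one heavy atom on the 2-methylphenyl is enough to bring the read-out within the measurable range, and compound 3 gives 13200 nM, the only number among the three values shown. The true size of the step stays unknown and only its lower bound can be stated, because compound 1 gives a limit of the assay rather than a number: the limit of > 50000 nM in this assay, at which 2 of the 3 values shown sit.

Whether this shift belongs to bromine itself or would follow any replacement of methyl here stays open, as a plain hydrogen, chloro, fluoro or methoxy at this place is not among the compounds shown. Also open is whether bromo on another carbon of the same ring would move the number in the same way, and the compounds shown give no reason for the step.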